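Swapping the ester side chain of compound 3 for a fluorinated ring

The compounds below may be only part of what the source reports. "The series", "measured", "known", "first", "only" and "open" are said of these compounds alone.

Measured compounds:
Compound 1, `COc1cc(O)c(C(=O)OCC2CCCCC2)c(/C=C/CN2C(=O)C=CC2=O)c1`, 7710 nM
Compound 2, `C=CS(=O)(=O)NC/C=C/c1cc(OC)cc(O)c1C(=O)OCc1ccc(Br)cc1`, 6240 nM
Compound 3, `C=CS(=O)(=O)NC/C=C/c1cc(OC)cc(O)c1C(=O)OCC1CCCCC1`, 7880 nM

All three were tested in a functional assay on THP-1 cells (Homo sapiens) for antiproliferative activity, read by luminescence, with a stated time of 72 h; on this read-out higher numbers stand for weaker inhibition and lower numbers for stronger inhibition. Compound 3 gives 7880 nM, the highest of the three numbers, but its neighbours sit within the scatter: compound 1 is nearest and compound 2 is furthest, and neither gap counts as a real difference. The step of a 1.0-fold higher number from compound 1 to compound 3 (0.01 log units; within the scatter) changes the group on the saturated chain carbon bound to a double-bonded chain carbon; the step of a 1.3-fold higher number from compound 2 to compound 3 (0.10 log units; within the scatter) changes the group on the saturated chain carbon bound to an oxygen next to a carbonyl group.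

Compound 4, `C=CS(=O)(=O)NC/C=C/c1cc(OC)cc(O)c1C(=O)OCc1ccc(F)cc1`, has not yet been measured. It differs from compound 3 by 4-fluorophenyl in place of cyclohexyl on a saturated chain carbon bound to an oxygen next to a carbonyl group. The step that bears on this is a 1.3-fold higher number from compound 2 to compound 3 (0.10 log units; within the scatter), since it replaces an aromatic ring at the same place with cyclohexyl and stays within the scatter. Reversing that kind of change should likewise move the number little. Compound 4 is therefore expected to lie close to compound 3, with a 1.2-fold lower number from compound 3 to compound 4 (0.06 log units; within the scatter) as the estimated step. The expected value for compound 4 is 6800 nM, with a likely range from 3200 nM to 14500 nM.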

Compound 4, half-maximal inhibitory concentration: 6550 nM
Compound 4: middle estimate off by 1.0-fold (0.02 log units), on the high side; the measured number falls inside the stated range.
By their numbers in this assay, from the lowest: compounds 2, 4, 1 and 3 (each within the scatter of the next).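

In this assay, 4-fluorophenyl in place of cyclohexyl gives a 1.2-fold lower number from compound 3 to compound 4 (0.08 log units; within the scatter) at the saturated chain carbon bound to an oxygen next to a carbonyl group, so this swap between a non-aromatic and an aromatic ring again stays inside the scatter, now with a second aromatic ring. The new information is the change on the aromatic ring itself: fluoro in place of bromo on an aromatic carbon gives a 1.0-fold higher number from compound 2 to compound 4 (0.02 log units; within the scatter) and so makes no readable difference between compound 2 and compound 4. No measurement shown here offers an explanation for why these steps are so small.

As far as these compounds go, all four compounds lie within the scatter of one another, so it remains open whether an ester side chain carrying an amine or a carboxylic acid, or a longer chain leading to the ring, would shift the number beyond the scatter. From the compounds shown here alone, it also remains open whether a different group on the aromatic ring, such as a methoxy or a nitrile, would stay as close to compound 4 as bromo does.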